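A Methoxymethoxy Variant of a Trimethoxy Acetophenone

The source may hold more compounds than are shown below. What is called first, only, known or untested is meant among the compounds shown, and "the series" means these compounds.

Of the compounds shown here, two from this series have been measured in a functional assay on A549 cells (Homo sapiens) for cytotoxicity, read by resazurin assay, with a stated time of 72 h; on this read-out lower numbers stand for stronger inhibition and higher numbers for weaker inhibition. Compound 1 `COc1cc(OC)c(C(C)=O)c(OC)c1` gives 9800 nM in this assay. Compound 2 `COc1cc(OC)c(C(=O)/C=C/c2ccccc2)c(OC)c1Cc1ccccc1O`, a far larger molecule carrying a cinnamoyl group and a phenol-bearing benzyl group on the same core, gives 9300 nM in this assay. The two numbers lie within the usual scatter of each other, so on the numbers shown compound 1 stands alongside compound 2 rather than apart from it, and neither the added groups of compound 2 nor their absence in compound 1 changes the read-out beyond the scatter.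

Compound 3 `COCOc1cc(OC)cc(OC)c1C(C)=O` has not yet been measured. It differs from compound 1 by methoxy in place of hydrogen on a saturated chain carbon bound to an oxygen on an aromatic ring; cut one bond further out, the same difference reads methoxy to methoxymethoxy. For the measured compounds named here, no step between two measured compounds matches this change. Given that compound 1 and compound 2 sit together despite their large difference, only a step of a 1.0-fold higher number from compound 1 to compound 3 (0.01 log units; within the scatter) is expected, none beyond the scatter. Compound 3 is therefore estimated to give 10000 nM in this assay, with an expected range from 4000 nM to 25000 nM.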

Compound 3, half-maximal inhibitory concentration: 16900 nM
Estimate against measurement, compound 3: 1.7-fold (0.23 log units) below; the range from low to high includes it.
By their numbers in this assay, from the lowest: compounds 2, 1 and 3 (each within the scatter of the next).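

For the compounds shown here, this is the first reading of a change at this position on its own: in this assay, methoxy in place of hydrogen on a saturated chain carbon bound to an oxygen on an aromatic ring gives a 1.7-fold higher number from compound 1 to compound 3 (0.24 log units; within the scatter) and so stays within the scatter. The earlier pair differed in more than one place and could not isolate this position, whereas this single step shows that replacing methoxy with methoxymethoxy on the shared core does not move the read-out beyond the scatter. No measurement at hand bears on this result.

The compounds shown leave open whether a different group at this place, such as a longer chain like butoxy, an amine or a carboxylic acid, would move the number beyond the scatter, since methoxymethoxy is the only replacement of methoxy shown here. They also leave open whether methoxymethoxy would give a similar step on a core carrying a cinnamoyl group, as the one step shown rests on the acetophenone compounds alone.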